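Replacing the 4-(methylsulfanyl)phenyl group of compound 2

A few compounds are considered here, and "the series" means these few. Any claim that something is new, unique, unknown or untested is made for them only; others in the source may bear on it.

Measured so far in a functional assay on HL-60 cells (Homo sapiens) for antiproliferative activity, read by MTT assay, with a stated time of 72 h; on this read-out higher numbers stand for weaker inhibition and lower numbers for stronger inhibition:
Compound 1 `COc1cc(C(=O)c2sc3ccccc3c2-c2ccccc2)cc(OC)c1OC` gives 1700 nM
Compound 2 `COc1cc(C(=O)c2sc3ccccc3c2-c2ccc(SC)cc2)cc(OC)c1OC` gives 1300 nM
Compound 3 `CCOc1ccc(-c2c(C(=O)c3cc(OC)c(OC)c(OC)c3)sc3ccccc23)cc1` gives 3500 nM

Compound 2 lies at the low end of these three numbers, with a 1.3-fold lower number from compound 1 to compound 2 (0.12 log units; within the scatter) and a 2.7-fold higher number from compound 2 to compound 3 (0.43 log units; beyond the scatter) as its two steps. The next compound, compound 4 `COc1cc(C(=O)c2sc3ccccc3c2Nc2ccc(Cl)cc2)cc(OC)c1OC`, differs from it as follows: (4-chlorophenyl)amino in place of 4-(methylsulfanyl)phenyl on an aromatic carbon. In short, (4-chlorophenyl)amino stands in place of 4-(methylsulfanyl)phenyl, on an aromatic carbon of a five-membered aromatic ring with 1 sulfur.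

The measured steps bear on this only loosely. Each swaps one group on an aromatic carbon, and none puts an amino link on the shared core. The remaining one, a 2.1-fold higher number from compound 1 to compound 3 (0.31 log units; beyond the scatter), is modest, like the largest step seen. No direction can be read from them, so no step beyond the scatter is expected, although the untested link keeps the range wide. The expected change is a 1.2-fold higher number from compound 2 to compound 4 (0.06 log units; within the scatter), an estimate only. In this assay compound 4 is expected near 1500 nM, with an estimated range from 300 nM to 7000 nM.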

Compound 4, half-maximal inhibitory concentration: 5400 nM
Estimate against measurement, compound 4: 3.6-fold (0.56 log units) below, within the range that was stated.
By their numbers in this assay, from the lowest: compounds 2 and 1 (each within the scatter of the next); then compounds 3 and 4 (each within the scatter of the next).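

In this assay, within the data shown here, the (4-chlorophenyl)amino group is the first change at this aromatic carbon that puts an amino link on the shared core, and it gives a 4.2-fold higher number from compound 2 to compound 4 (0.62 log units; beyond the scatter) together with a 3.2-fold higher number from compound 1 to compound 4 (0.50 log units; beyond the scatter) as steps beyond the scatter. Against the 4-ethoxyphenyl group the same change gives only a 1.5-fold higher number from compound 3 to compound 4 (0.19 log units; within the scatter) and so leaves compound 3 and compound 4 unseparated, which means the amino-linked group falls with the weaker of the earlier compounds in this assay. No measurement at hand accounts for this result.

As far as these compounds go, compound 4 brings in the amino link and the chlorine together, so it stays open which of them goes with the higher numbers. A plain phenylamino group or a 4-chlorophenyl group set directly on the core would separate the two, and a phenoxy link remains an open alternative.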